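From 2-fluorophenyl to chloromethyl on a carbonyl carbon

The source may hold more compounds than are shown below. What is called first, only, known or untested is meant among the compounds shown, and "the series" means these compounds.

In a functional assay on HeLa cells (Homo sapiens) for cytotoxicity, read by MTT assay, with a stated time of 72 h (on this read-out higher numbers stand for weaker inhibition and lower numbers for stronger inhibition), compound 1 (`O=[N+]([O-])c1ccc(/N=N/Nc2ccc([N+](=O)[O-])cc2Br)c(Br)c1`) gives 940 nM and compound 2 (`O=C(c1ccccc1F)N(/N=N/c1ccc([N+](=O)[O-])cc1Cl)c1ccc([N+](=O)[O-])cc1Cl`) gives 2350 nM as the higher of the two numbers, which makes it the weaker of the pair by a gap beyond the usual scatter of repeats. Among the compounds with values here, compound 3 (`O=C(CCl)N(/N=N/c1ccc([N+](=O)[O-])cc1Cl)c1ccc([N+](=O)[O-])cc1Cl`) has no measurement yet. Its change from compound 2 is chloromethyl in place of 2-fluorophenyl on a carbonyl carbon and in words this is chloromethyl in place of 2-fluorophenyl on a carbonyl carbon. Within the data shown here, no measured pair shows this change alone, so the only guide is the span from compound 1 at 940 nM to compound 2 at 2350 nM and the estimate stays inside it. The expected step is small, a 1.6-fold lower number from compound 2 to compound 3 (0.19 log units; within the scatter) toward a lower number and within the scatter. For compound 3 the estimated value is 1500 nM with a likely range from 450 nM to 5000 nM in this assay.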

Compound 3, half-maximal inhibitory concentration: 550 nM
For compound 3 the middle estimate is 2.7-fold (0.44 log units) above the measured one, and the stated range covers the measured number.
By their numbers in this assay, from the lowest: compounds 3 and 1 (each within the scatter of the next); then compound 2.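

Within the data shown here, changing the group on this carbonyl carbon gives the first step that can be read at this position. In this assay it is a 4.3-fold lower number from compound 2 to compound 3 (0.63 log units; beyond the scatter), so what sits on the carbonyl carbon matters on these cells, and the step lies beyond the usual scatter of repeats. The aromatic ring of 2-fluorophenyl is also not required for activity here, as chloromethyl, with no ring and only 2 heavy atoms in place of 7, gives the lower number, but nothing at hand explains the gain.

From the compounds shown here alone, what stays open is whether the chlorine of chloromethyl counts or the loss of the ring alone, a question that a plain methyl group on this carbonyl carbon would answer. Going by these compounds, how a longer chain or an amine would fare at this place also remains open.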